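The compounds below may be only part of what the source reports. "The series", "measured", "known", "first", "only" and "open" are said of these compounds alone.

Of the compounds shown here, three sharing one core have been measured in a functional assay on HepG2 cells (Homo sapiens) for cytotoxicity, read by MTT assay, with a stated time of 24 h (a lower number here means a stronger inhibitor, a higher number a weaker inhibitor), so far. Compound 1 `COc1cc(/C=C2\CN(C)C/C(=C\c3cccnc3)C2=O)cc(OC)c1` gives 6910 nM while compound 2 `CN1C/C(=C\c2cccnc2)C(=O)/C(=C/c2ccccc2F)C1` gives 4810 nM and compound 3 `CN1C/C(=C\c2cccnc2)C(=O)/C(=C/c2cc([N+](=O)[O-])ccc2F)C1` gives 6630 nM with all three within the scatter of one another. Compound 2 therefore stands level with the other two.

Compound 4 `CN1C/C(=C\c2ccc(C#N)cc2)C(=O)/C(=C/c2cccnc2)C1` has 4-cyanophenyl in place of 2-fluorophenyl on a double-bonded chain carbon bound to a double-bonded ring carbon, and the swap counts out as 4-cyanophenyl in place of 2-fluorophenyl on a double-bonded chain carbon bound to a double-bonded ring carbon in full. Among the compounds with values here, the one measured step that bears on this is a 1.4-fold higher number from compound 2 to compound 3 (0.14 log units; within the scatter) for nitro in place of hydrogen on an aromatic carbon, and it stays within the scatter. Compound 1 also carries a different aromatic group and gives 6910 nM in the same range. No change beyond the scatter is therefore expected in this assay and the estimate amounts to a 1.1-fold higher number from compound 2 to compound 4 (0.06 log units; within the scatter) with no firm direction. For compound 4 the estimated value is 5500 nM with an expected range from 2800 nM to 10500 nM in this measurement.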

Compound 4, half-maximal inhibitory concentration: 12700 nM
Compound 4: the middle estimate sits 2.3-fold (0.36 log units) below what was measured, and the stated range ends below it.
By their numbers in this assay, from the lowest: compounds 2, 3, 1 and 4 (each within the scatter of the next, the first and the last beyond it).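

In this assay, within the data shown here, putting 4-cyanophenyl in place of 2-fluorophenyl on a double-bonded chain carbon bound to a double-bonded ring carbon gives a 2.6-fold higher number from compound 2 to compound 4 (0.42 log units; beyond the scatter), the first single change here to pass the scatter, whereas nitro in place of hydrogen on an aromatic carbon gave a 1.4-fold higher number from compound 2 to compound 3 (0.14 log units; within the scatter) and stayed within it. The number can therefore move with what sits at this position, though only modestly, and this change makes the compound a weaker inhibitor. No measurement at hand accounts for this step.

The swap removes the fluorine and brings in the nitrile in one move, so these compounds cannot separate the two parts of the change. On these data alone, whether an amine or a carboxylic acid on the phenyl ring at this position would shift the number further, and in which direction, remains open.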